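From Sulfanyl to Oxy at the Toxicity Limit

The source may hold more compounds than are shown below. What is called first, only, known or untested is meant among the compounds shown, and "the series" means these compounds.

In an ADME assay on HEK293 cells (Homo sapiens) for cytotoxicity, read by resazurin assay, with a stated time of 72 h (on this read-out higher numbers stand for lower toxicity in this test and lower numbers for higher toxicity in this test), compound 1 `CCc1cccc(CNC(=O)c2nc3cccc(COc4ccc(CC(=O)O)cc4)c3c(=O)[nH]2)c1` reaches only a limit, > 20000 nM. Compound 2 `CCc1cccc(CNC(=O)c2nc3cccc(COc4ccc(C(=O)O)cc4)c3c(=O)[nH]2)c1` also gives only a limit, > 20000 nM. Compound 3 `CCc1cccc(CNC(=O)c2nc3cccc(CSCc4ccc(C(=O)O)cc4)c3c(=O)[nH]2)c1` likewise stands at a limit, > 20000 nM, so the series sits at the limit of > 20000 nM in this assay, at which 3 of the 3 values shown sit. Compound 4 `CCc1cccc(CNC(=O)c2nc3cccc(COCc4cccc(C(=O)O)c4)c3c(=O)[nH]2)c1` differs from it in one place: (3-carboxybenzyl)oxy in place of (4-carboxybenzyl)sulfanyl on a saturated chain carbon bound to an aromatic carbon. Three measured steps changed the same group: a step that the two limits leave unreadable from compound 1 to compound 2, a step that the two limits leave unreadable from compound 1 to compound 3 and a step that the two limits leave unreadable from compound 2 to compound 3. None has a readable size, and none points in a direction. On this basis, no step beyond the scatter is expected in this assay, in either direction. The expected change is a step that the limit leaves unreadable from compound 3 to compound 4. For compound 4 the estimate is 30000 nM, with an expected range from 15000 nM to 60000 nM.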

Compound 4, half-maximal cytotoxic concentration: > 20000 nM
Compound 4 gave a limit, no number (the forecaster's own chance of this, stated with the estimate: 85%); the middle value is on the limit's open side.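

Compound 4 also gives only a limit, so its steps from compound 1, compound 2 and compound 3 cannot be read in this assay: the limit of > 20000 nM in this assay, at which 4 of the 4 values shown sit.

The compounds shown leave open at what concentration, if any, each would become toxic to these cells.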